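Oxazole in place of imidazole on the amide carbonyl

The source may hold more compounds than are shown below. What is called first, only, known or untested is meant among the compounds shown, and "the series" means these compounds.

Compound 1 `COc1ccc(-c2cnc(NC(=O)c3ncc[nH]3)n2C)cc1` was tested in a toxicity assay on THP-1 cells (Homo sapiens) for inhibition; on this read-out lower numbers stand for higher toxicity in this test and higher numbers for lower toxicity in this test. In this assay compound 1 reaches only the limit of the test, > 100000 nM, so no number is known for it. Compound 2 `Cn1c(-c2ccccc2F)cnc1NC(=O)c1ccc(F)cc1` was also tested, and in this assay compound 2 likewise reaches only the limit, > 100000 nM. Both results sit at the same limit (the limit of > 100000 nM in this assay, at which 2 of the 2 values shown sit), so compound 1 stands where every value shown stands, without a measured number to rank it.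

Compound 3 `COc1ccc(-c2cnc(NC(=O)c3cnco3)n2C)cc1` has not yet been measured. It differs from compound 1 in one place: 1,3-oxazol-5-yl in place of 1H-imidazol-2-yl on a carbonyl carbon. Among the measured compounds shown here, no pair of measured compounds differing in one place is available to show how large such a step is, so the expected step in this assay from compound 1 to compound 3 is none beyond the scatter, a step that the limit leaves unreadable from compound 1 to compound 3. Compound 3 is therefore estimated at 150000 nM, with a range from 50000 nM to 400000 nM.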

Compound 3, half-maximal cytotoxic concentration: > 100000 nM
Compound 3: no number, only a limit; the forecaster's own chance of this, stated with the estimate: 85%; the middle value does not contradict the limit.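

Compound 1 and compound 3 both stop at a limit of the test in this assay, so no step between them can be read: the limit of > 100000 nM in this assay, at which 3 of the 3 values shown sit.

The compounds shown leave open how 1,3-oxazol-5-yl compares with 1H-imidazol-2-yl on this read-out, and at what concentration any of them would become toxic to these cells.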